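Swapping a hydroxyphenyl position on a pyridine-free shared core

The compounds below may be only part of what the source reports. "The series", "measured", "known", "first", "only" and "open" are said of these compounds alone.

Compound 1 `Oc1cccc(-c2cc(-c3cccc(F)c3)cc(-c3ccccc3O)n2)c1` is tested in a functional assay on DU-145 cells (Homo sapiens) for inhibition (a higher number here means a weaker inhibitor, a lower number a stronger inhibitor), where compound 1 gives only a limit of the assay, > 50000 nM. Compound 2 `Oc1cccc(-c2cc(-c3cccc(F)c3)cc(-c3cccc(O)c3)n2)c1` gives 23800 nM in this assay, so the change 3-hydroxyphenyl in place of 2-hydroxyphenyl on an aromatic carbon brings an at least 2.1-fold lower number from compound 1 to compound 2 (0.32 log units; beyond the scatter). Compound 3 `Oc1ccccc1-c1cc(-c2ccccc2C(F)(F)F)cc(-c2ccccc2O)n1` gives 4770 nM in this assay; how the core of compound 3 differs from the core of compound 1 is not broken down here. Compound 4 `Oc1cccc(-c2cc(-c3ccccc3C(F)(F)F)cc(-c3ccccc3O)n2)c1` carries the change (3-hydroxyphenyl in place of 2-hydroxyphenyl on an aromatic carbon). This is the same kind of change as in compound 2, but the place differs: in compound 4 it is meta to a 2-(trifluoromethyl)phenyl group and meta to a 2-hydroxyphenyl group, whereas in compound 2 it is meta to a 3-fluorophenyl group and meta to a 3-hydroxyphenyl group. Because an at least 2.1-fold lower number from compound 1 to compound 2 (0.32 log units; beyond the scatter) was observed, a step of a 2.4-fold lower number from compound 3 to compound 4 (0.38 log units; beyond the scatter) is expected for compound 4. Compound 4 is thus estimated to give 2000 nM in this assay, between 700 nM and 6000 nM.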

Compound 4, half-maximal inhibitory concentration: 7250 nM
Compound 4: the middle estimate sits 3.6-fold (0.56 log units) below what was measured; measured number outside the range, above it.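

In this assay, the change from 2-hydroxyphenyl to 3-hydroxyphenyl did not carry over from one core to the other, as the two steps differ: the same change on two cores in this assay, an at least 2.1-fold lower number (0.32 log units; beyond the scatter) from compound 1 to compound 2 and a 1.5-fold higher number (0.18 log units; within the scatter) from compound 3 to compound 4, at least 3.1-fold (0.50 log units) apart, beyond the scatter of two such steps. The second step alone reads a 1.5-fold higher number from compound 3 to compound 4 (0.18 log units; within the scatter), while 2-(trifluoromethyl)phenyl in place of 3-fluorophenyl gives an at least 6.8-fold lower number from compound 1 to compound 4 (0.83 log units; beyond the scatter). Compound 1 gives only a limit of the assay, so the steps from it have no exact size, and two cores cannot show how the change behaves on any other: the limit of > 50000 nM in this assay, at which 1 of the 4 values shown sits.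

The compounds shown leave open how the change would read on further cores. They also leave open whether an amine or a carboxylic acid in place of the hydroxyl would alter the number.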